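A few compounds are considered here, and "the series" means these few. Any claim that something is new, unique, unknown or untested is made for them only; others in the source may bear on it.

In a functional assay on MDA-MB-231 cells (Homo sapiens) for antiproliferative activity, read by MTT assay, with a stated time of 48 h (a lower number here means a stronger inhibitor, a higher number a weaker inhibitor), compound 1 (`C=CS(=O)(=O)N1CCN(c2ncnc3sc(-c4ccc(OC)nc4)cc23)CC1`) gives 9270 nM and compound 3 (`CN1CCN(c2ccc(-c3cc4c(N5CCN(S(=O)(=O)N6CCCCC6)CC5)ncnc4s3)cc2)CC1`) gives 8130 nM, two numbers within the usual scatter of each other. Compound 2 (`C=CS(=O)(=O)N1CCN(c2nc(OC[C@H]3CCCN3C)nc3sc(-c4ccc(N5CCN(C)CC5)cc4)cc23)CC1`) gives 760 nM, a number lower than that of compound 3 by a margin well beyond the scatter. Compound 3 therefore stands at the weak end of this small set, alongside compound 1.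

Compound 4 (`CN1CCN(c2ccc(-c3cc4c(N5CCN(C(=O)Nc6ccc(Cl)cc6)CC5)ncnc4s3)cc2)CC1`) keeps the rest of compound 3 and changes one group: (4-chlorophenyl)carbamoyl in place of (piperidin-1-yl)sulfonyl on an amine nitrogen in a ring. In short, (4-chlorophenyl)carbamoyl takes the place of (piperidin-1-yl)sulfonyl on an amine nitrogen in a ring.

Going by the values given here, no pair of measured compounds isolates a change at this place, so the direction is an expectation with weak support. Compound 2 at 760 nM shows only that this set can reach well under the number of compound 3. A modest move toward a lower number is expected in this assay, and the estimated change is a 2.7-fold lower number from compound 3 to compound 4 (0.43 log units; beyond the scatter). For compound 4 the expected value is 3000 nM, with an estimated range from 800 nM to 10000 nM.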

Compound 4, half-maximal inhibitory concentration: 5440 nM
Compound 4: middle estimate off by 1.8-fold (0.26 log units), on the low side; the measured number falls inside the stated range.
By their numbers in this assay, from the lowest: compound 2; then compounds 4, 3 and 1 (each within the scatter of the next).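

In this assay, putting (4-chlorophenyl)carbamoyl in place of (piperidin-1-yl)sulfonyl on the amine nitrogen in the ring gives a 1.5-fold lower number from compound 3 to compound 4 (0.17 log units; within the scatter), so compound 3 and compound 4 cannot be told apart. Going by these compounds alone, this is a direct reading at this place, which the earlier compounds did not give: two groups that differ in their ring, in the link to the nitrogen and in their hydrogen-bond donors give numbers within the usual scatter of each other. No measured evidence here accounts for this result.

The ring and the link were exchanged together, so this pair does not show what either contributes alone; a (piperidin-1-yl)carbonyl or a phenylsulfonyl group on the same nitrogen would separate them. Going by these compounds, whether an acetyl group or a plain hydrogen there would give a number beyond the scatter also stays open.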